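Replacing 4-carboxyphenyl with pyridin-4-yl in compound 3

A few compounds are considered here, and "the series" means these few. Any claim that something is new, unique, unknown or untested is made for them only; others in the source may bear on it.

In an ADME assay (liver) for metabolic stability, with Liver microsome (Homo sapiens) as the target, using microsomes (a lower number here means that the compound disappears faster, a higher number that the compound lasts longer), compound 1 (`CCc1nc2cc(Cl)ccn2c1C(=O)NCc1ccc(-c2ccc(C)cc2)cc1`) gives 0.423 h on the shared core. Compound 2 (`CCc1nc2cc(Cl)ccn2c1C(=O)NCc1ccc(-c2ccc(C(=O)O)cc2)cc1`) gives > 2 h and this is a limit, not a number (the limit of > 2 h in this assay, at which 1 of the 2 values shown sits). Compound 3 (`CCc1nc2cc(Cl)ccn2c1C(=O)NCc1ccc(-c2ccncc2)cc1`) carries pyridin-4-yl in place of 4-carboxyphenyl on an aromatic carbon. Among the compounds with values here, the one measured step bearing on this is an at least 4.7-fold higher number from compound 1 to compound 2 (0.67 log units; beyond the scatter) and compound 3, like compound 1, has no carboxy group. A fall of comparable size is therefore expected in this assay and the estimated move is an at least 2.5-fold lower number from compound 2 to compound 3 (0.39 log units; beyond the scatter) for now. Compound 3 is expected at 0.8 h (range 0.3 h to 2.2 h).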

Compound 3, half-life: 0.482 h
Compound 3: middle estimate off by 1.7-fold (0.22 log units), on the high side; the measured number falls inside the stated range.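

In this assay, the change to pyridin-4-yl on this aromatic carbon gives an at least 4.1-fold lower number from compound 2 to compound 3 (0.61 log units; beyond the scatter). Against the methyl-bearing compound, the same change gives a 1.1-fold higher number from compound 1 to compound 3 (0.06 log units; within the scatter), so pyridin-4-yl and 4-methylphenyl cannot be told apart here, and only compound 2, with its carboxy group, stands apart. Compound 2 sits at a limit, so the full size of its steps stays open: the limit of > 2 h in this assay, at which 1 of the 3 values shown sits.

Going by these compounds, whether a primary carboxamide or a hydroxyl group in place of the carboxy group would also keep the number high remains open. So does the effect of an amine at this position.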